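The compounds below may be only part of what the source reports. "The series", "measured", "known", "first", "only" and "open" are said of these compounds alone.

Three compounds sharing one core were tested in an assay on isolated protein for displacement of a labelled ligand from metabotropic glutamate receptor 5 (Homo sapiens), with a stated time of 60 min, tested at 1 uM; on this read-out lower numbers stand for less inhibition and higher numbers for more inhibition at the one concentration tested (going by the name of the read-out). Compound 1 `CC1CCN(c2c(S(=O)(=O)c3cc(Cl)cc(Cl)c3)cnc3ccc(Cl)cc23)CC1` gives 88%, compound 2 `CC1CCN(c2c(S(=O)(=O)c3ccc(F)cc3)cnc3ccc(Cl)cc23)CC1` gives 89%, and compound 3 `CC1CCN(c2c(S(=O)(=O)c3ccc(C#N)cc3)cnc3ccc(Cl)cc23)CC1` gives 31%, the lowest of the three. Between the two halogenated compounds the step was small, a number 1 percentage points higher from compound 1 to compound 2 (within the scatter), whereas a number 57 percentage points lower from compound 1 to compound 3 (beyond the scatter) and a number 58 percentage points lower from compound 2 to compound 3 (beyond the scatter). Compound 4 `CC1CCN(c2c(S(=O)(=O)c3cc(F)cc(F)c3)cnc3ccc(Cl)cc23)CC1` has not yet been measured in this assay; it differs from compound 3 by 3,5-difluorophenyl in place of 4-cyanophenyl on a sulfonyl sulfur. Both large steps bear on this change, since the entering 3,5-difluorophenyl shares its pattern with the 3,5-dichlorophenyl of compound 1 and its fluorine with the 4-fluorophenyl of compound 2. For compound 4 the expected step is therefore large and upward, a number 53 percentage points higher from compound 3 to compound 4 (beyond the scatter). Compound 4 is estimated at 84%, within 65% to 95%.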

Compound 4, a percentage reported as inhibition, at one concentration (the size of the read-out at that concentration, not a potency): 93%
Estimate against measurement, compound 4: 9 percentage points below; the range from low to high includes it.
By their numbers in this assay, from the lowest: compound 3; then compounds 1, 2 and 4 (each within the scatter of the next).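

In this assay, the change away from 4-cyanophenyl on the sulfonyl sulfur is large, a number 62 percentage points higher from compound 3 to compound 4 (beyond the scatter). Among the halogen-bearing phenyl groups the new compound does not separate from the others, a number 4 percentage points higher from compound 2 to compound 4 (within the scatter) and a number 5 percentage points higher from compound 1 to compound 4 (within the scatter). This position thus takes 3,5-difluorophenyl, 4-fluorophenyl and 3,5-dichlorophenyl alike, with compound 3 alone standing apart. Nothing measured here accounts for that difference. Still open, on these data alone, is whether a phenyl carrying an amine, a carboxylic acid or a methoxy group would read like compound 3 or like compound 4.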